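A Dihydroxyphenyl Amide Awaits Its Cytotoxicity Reading

A few compounds are considered here, and "the series" means these few. Any claim that something is new, unique, unknown or untested is made for them only; others in the source may bear on it.

compound 1 `O=C(Nc1cc(C(F)(F)F)cc(C(F)(F)F)c1)c1ccccc1O`: 12000 nM
compound 2 `O=C(Nc1cc(C(F)(F)F)cc(C(F)(F)F)c1)c1cc(F)ccc1O`: 2500 nM

In an ADME assay on cells (Macrophage, Mus musculus) for cytotoxicity, read by resazurin assay, with a stated time of 3 days (on this read-out lower numbers stand for stronger inhibition and higher numbers for weaker inhibition), compound 1 gives 12000 nM and compound 2 gives 2500 nM. Compound 2 holds the lowest number of the two; its nearest neighbour is compound 1, with a 4.8-fold lower number from compound 1 to compound 2 (0.68 log units; beyond the scatter). Compound 3 `O=C(Nc1cc(C(F)(F)F)cc(C(F)(F)F)c1)c1cccc(O)c1O` carries 2,3-dihydroxyphenyl in place of 5-fluoro-2-hydroxyphenyl on a carbonyl carbon. Among the compounds with values here, the one measured step, a 4.8-fold lower number from compound 1 to compound 2 (0.68 log units; beyond the scatter), concerns fluoro in place of hydrogen on an aromatic carbon; in compound 3 that fluorine leaves again while a second hydroxy enters, a change for which no step has been measured. He therefore expects compound 3 to give a higher number, a 3.2-fold higher number from compound 2 to compound 3 (0.51 log units; beyond the scatter), estimated at 8000 nM within 2500 nM to 25000 nM.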

Compound 3, half-maximal inhibitory concentration: 1700 nM
Compound 3: the middle estimate sits 4.7-fold (0.67 log units) above what was measured; measured number outside the range, below it.
By their numbers in this assay, from the lowest: compounds 3 and 2 (each within the scatter of the next); then compound 1.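

In this assay, a second hydroxy on the aromatic carbon of compound 1 also lowers the number, not only a fluoro, with a 7.1-fold lower number from compound 1 to compound 3 (0.85 log units; beyond the scatter). Putting 2,3-dihydroxyphenyl in place of 5-fluoro-2-hydroxyphenyl on the carbonyl carbon gives a 1.5-fold lower number from compound 2 to compound 3 (0.17 log units; within the scatter), so this read-out does not tell the two groups apart. Nothing at hand explains either step. From the compounds shown here alone, whether a methoxy or an amine in place of the second hydroxy would keep the number near those of compound 2 and compound 3 stays open. So does the outcome of a fluoro and a second hydroxy together on one ring.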